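The source may report more compounds than this note shows. Statements on the series, on what has been measured and on what is new or still open speak of the compounds shown alone.

Measured so far in an assay on CHO cells for displacement of a labelled ligand from adenosine receptor A1 (Homo sapiens), read by scintillation counting, tested at 10 uM; on this read-out higher numbers stand for more inhibition at the one concentration tested (going by the name of the read-out) and lower numbers for less inhibition:
compound 1, `CC(C)(C)Cc1c(-c2ccccn2)sc(N)c1C(=O)c1ccc(Cl)cc1`: 1%
compound 2, `CC(C)(C)Cc1csc(N)c1C(=O)c1cccc(C(F)(F)F)c1`: 1%
compound 3, `Cc1ccc(C(=O)c2c(N)sc(Br)c2CC(C)(C)C)cc1`: 1%

All three compounds share one core, built around a five-membered aromatic ring with one sulfur, and all three sit at the floor of the read-out. In this assay compound 1 gives 1%, and compound 2 gives 1% while compound 3 gives 1%. The three numbers are level at the digits shown, so compound 1 is neither set apart from its nearest companion, compound 2, nor from its furthest, compound 3; none of the three shows any displacement worth the name.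

Compound 4, `Cc1noc(C)c1-c1sc(N)c(C(=O)c2ccc(Cl)cc2)c1CC(C)(C)C`, differs from compound 1 in a single place: 3,5-dimethyl-1,2-oxazol-4-yl in place of pyridin-2-yl on an aromatic carbon. Going by the values given here, no pair of measured compounds differing in only one place exists here, so there is no measured step to lean on. What the data do show is that compounds 2 and 3, which differ from compound 1 in more than one place, give the same low read-out as compound 1. On that basis, the step from compound 1 to compound 4 is expected to be none beyond the scatter, and the estimate for compound 4 in this assay is 2%, within 0% to 12%, which means an expected step of a number 1 percentage points higher from compound 1 to compound 4 (within the scatter).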

Compound 4, a percentage reported as inhibition, at one concentration (the size of the read-out at that concentration, not a potency): 1%
Compound 4: the middle estimate sits 1 percentage points above what was measured; low and high end bracket the measured number.
By their numbers in this assay, from the lowest: compounds 1, 2, 3 and 4 (each within the scatter of the next).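

In this assay, going by these compounds alone, this is the first comparison of two compounds that differ in one place only, and it gives no change at the digits printed from compound 1 to compound 4 (within the scatter). On this aromatic carbon next to the ring sulfur, a five-membered 3,5-dimethyl-1,2-oxazol-4-yl ring can stand in for the six-membered pyridin-2-yl ring without moving the read-out. Within the data shown here, both compounds sit at the floor, so the step says only that neither ring brings measurable displacement at the one concentration tested, and nothing available explains the result.

The compounds shown leave open whether an amine, a carboxylic acid or a longer alkyl chain on this carbon would give more displacement than these two rings. They also leave open whether this position matters at all in a compound with clear displacement.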